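Adding a Hydroxy to a Macrocyclic Bisphenol Ether

The source may report more compounds than this note shows. Statements on the series, on what has been measured and on what is new or still open speak of the compounds shown alone.

Measured compounds:
compound 1 `COC1Cc2cccc(c2)Oc2c(O)cccc2CCc2ccc(cc2)Oc2cc1cc(O)c2O` with 62200 nM
compound 2 `Oc1ccc2c(c1)CCc1ccc(O)c(c1)-c1cc(ccc1O)/C=C\c1cccc(c1)O2` with a limit of > 100000 nM

Compound 1 `COC1Cc2cccc(c2)Oc2c(O)cccc2CCc2ccc(cc2)Oc2cc1cc(O)c2O` in a functional assay on RAW264.7 cells (Mus musculus) for inhibition, read by Griess assay, with stated times of 1 h and 24 h (a higher number here means a weaker inhibitor, a lower number a stronger inhibitor), gives 62200 nM. Compound 2 `Oc1ccc2c(c1)CCc1ccc(O)c(c1)-c1cc(ccc1O)/C=C\c1cccc(c1)O2` in this assay gives only a limit, > 100000 nM. Compound 2 thus sits at the limit of > 100000 nM in this assay, at which 1 of the 2 values shown sits, and has no number of its own. Compound 3 `Oc1ccc2cc1-c1cc(ccc1O)CCc1c(ccc(O)c1O)Oc1cccc(c1)/C=C\2` differs from compound 2 by hydroxy in place of hydrogen on an aromatic carbon. Within the data shown here, since compound 2 offers only a limit, no measured step guides this change, and no step beyond the usual scatter is expected in this assay. Compound 3 is therefore estimated at 100000 nM, within 30000 nM to 300000 nM, an expected step of a number no higher from compound 2 to compound 3 (the limit leaves the size open).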

Compound 3, half-maximal inhibitory concentration: > 100000 nM
Compound 3 gave a limit, no number (the forecaster's own chance of this, stated with the estimate: 60%); the middle value lies on the limit itself.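

In this assay, among these compounds, compound 2 and compound 3 each give only a limit, and no step between them can be read. Going by these compounds, whether hydroxy in place of hydrogen on an aromatic carbon changes inhibition at all stays open.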